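A few compounds are considered here, and "the series" means these few. Any claim that something is new, unique, unknown or untested is made for them only; others in the source may bear on it.

Compound 3 `CCCN1CCN(c2ccc(S(=O)(=O)Oc3ccccc3C)cc2)C1=O` sits at the edge of what a functional assay on M21 cells (Homo sapiens) for antiproliferative activity, read by sulforhodamine B assay, with a stated time of 48 h (on this read-out lower numbers stand for stronger inhibition and higher numbers for weaker inhibition), can report. In this assay compound 3 gives > 100000 nM, which is a limit of the assay and not a number, (the limit of > 100000 nM in this assay, at which 1 of the 3 values shown sits). Compound 1 `Cc1ccccc1OS(=O)(=O)c1ccc(N2CCN(C)C2=O)cc1` gives 2900 nM in this assay, and the step of an at least 34-fold higher number from compound 1 to compound 3 (1.53 log units; beyond the scatter) shows how much is lost on the way to the limit. Compound 2 `CCN1CCN(c2ccc(S(=O)(=O)Oc3cc(OC)cc(OC)c3)cc2)C1=O` gives 4200 nM. Compound 4 `CCCN1CCN(c2ccc(S(=O)(=O)Oc3ccc(F)cc3)cc2)C1=O` is not yet measured and differs from compound 3 in one place: 4-fluorophenyl in place of 2-methylphenyl on an oxygen. No measured step touches this part of the molecule; the only step shown alters the chain on the ring nitrogen instead. The step of a number no higher from compound 3 to compound 4 (the limit leaves the size open) is therefore expected to stay small. Compound 4 is estimated at 100000 nM, within a range from 20000 nM to 300000 nM.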

Compound 4, half-maximal inhibitory concentration: 14000 nM
Compound 4: middle estimate off by 7.1-fold (0.85 log units), on the high side, outside the stated range (below it).
By their numbers in this assay, from the lowest: compounds 1 and 2 (each within the scatter of the next); then compound 4. At a limit, above all of these: compound 3.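

The group on the oxygen bound to the sulfonyl sulfur matters in this assay: 4-fluorophenyl in place of 2-methylphenyl gives an at least 7.1-fold lower number from compound 3 to compound 4 (0.85 log units; beyond the scatter). Until now, the only step shown had changed the chain on the ring nitrogen. Going by these compounds, compound 3 gives > 100000 nM, which is a limit of the assay and not a number, so the full size of this step stays open.

The swap removes a methyl group and adds a fluorine at once, and the compounds shown do not separate the two changes. On these data alone, how a plain phenyl or a 4-chlorophenyl group would behave on this oxygen also remains open.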